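Nitro in place of methyl: compound 3 to compound 4

The compounds below may be only part of what the source reports. "The series", "measured", "known", "first", "only" and "open" are said of these compounds alone.

Of the compounds shown here, three have been read so far in a functional assay on HL-60 cells (Homo sapiens) for inhibition, read by CCK-8 assay, with a stated time of 48 h, tested at 20 uM (a higher number here means more inhibition of growth at the concentration tested, a lower number less inhibition of growth), and their numbers lie close together. Compound 1 (`N#C/C(=C\c1ccccc1OS(=O)(=O)c1ccc([N+](=O)[O-])cc1)C(=O)Nc1nnc(-c2cccs2)s1`) gives 23% there, compound 2 (`N#C/C(=C\c1ccccc1OS(=O)(=O)c1ccc([N+](=O)[O-])cc1)C(=O)Nc1nnc(Cc2ccccc2)s1`) gives 20% there, and compound 3 (`Cc1ccc(S(=O)(=O)Oc2ccccc2/C=C(\C#N)C(=O)Nc2nnc(Cc3ccc(Cl)cc3)s2)cc1`) gives 15% there. Compound 3 stands within the scatter of both others, so the three numbers carry no order.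

The change to compound 4 (`N#C/C(=C\c1ccccc1OS(=O)(=O)c1ccc([N+](=O)[O-])cc1)C(=O)Nc1nnc(Cc2ccc(Cl)cc2)s1`) from compound 3 is nitro in place of methyl on an aromatic carbon and amounts to nitro in place of methyl on an aromatic carbon, with (4-methylphenyl)sulfonyl becoming (4-nitrophenyl)sulfonyl. For the measured compounds named here, no measured step isolates this change. Going by the values given here, the only single-place step so far is a number 3 percentage points lower from compound 1 to compound 2 (within the scatter) and it concerns benzyl in place of thiophen-2-yl, at another place in the molecule. It gives only weak guidance here. Compound 2, which carries the 4-nitrophenyl group, stands at 20% in this assay and so within the scatter of compound 3, though the two also differ elsewhere. In this assay the expected size is a number 5 percentage points higher from compound 3 to compound 4 (within the scatter) and no step beyond the scatter is anticipated. For compound 4 the estimated value is 20% with an expected range from 8% to 34% in this read-out.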

Compound 4, percent growth inhibition at one concentration: 34%
The estimate for compound 4 lay 14 percentage points below the measured number; the range from low to high includes it.
By their numbers in this assay, from the lowest: compounds 3, 2 and 1 (each within the scatter of the next); then compound 4.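

Nitro in place of methyl, on an aromatic carbon para to a large group, gives in this assay a number 19 percentage points higher from compound 3 to compound 4 (beyond the scatter) with the 4-chlorobenzyl group held constant, so the change from (4-methylphenyl)sulfonyl to (4-nitrophenyl)sulfonyl registers in this read-out, whereas the one earlier single-place step stayed within the scatter. With the (4-nitrophenyl)sulfonyl group held constant, the other end of the molecule also matters: chloro in place of hydrogen on the benzyl ring gives a number 14 percentage points higher from compound 2 to compound 4 (beyond the scatter) and 4-chlorobenzyl in place of thiophen-2-yl gives a number 11 percentage points higher from compound 1 to compound 4 (beyond the scatter) and both of these steps clear the scatter. Compound 4 therefore stands apart from all three other compounds in this assay and is the most active of the four at the single concentration tested, with changes at both ends of the molecule contributing.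

No measurement shown here gives a reason for any of these steps. Still open, on these data alone, is whether the rise is particular to nitro or would also appear with an amine, a carboxylic acid or a methoxy group at the same place on the ring, and whether it carries over to the thiophen-2-yl or unsubstituted benzyl compounds.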